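This account rests on a few compounds, and the source may have more. Where it says the series, first, only, none or still open, it means among the compounds named here.

Three compounds of the series have readings in a physicochemical assay for solubility, read by nephelometry, measured as kinetic solubility; a higher number here means a more soluble compound, a lower number a less soluble compound. Compound 1 (`CCC/N=C1\S/C(=C\c2ccc(C(=O)O)cc2)C(=O)N1c1ccccc1C`) gives 163000 nM, compound 2 (`CCC/N=C1\S/C(=C\c2ccc(C(=O)OC)c(Cl)c2)C(=O)N1c1ccccc1C`) gives 39000 nM, and compound 3 (`CCC/N=C1\S/C(=C\c2ccc(C(=O)NCC(=O)N(C)C)cc2)C(=O)N1c1ccccc1O`) gives 219000 nM. Compound 3 and compound 1 lie within the scatter of each other, while compound 2 sits lower than compound 3 by a margin beyond the scatter. Among the measured compounds shown here, these three differ in more than one place, so no measured step isolates a single change.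

Compound 4 (`CCC/N=C1\S/C(=C\c2ccc(C(=O)OCC(O)CO)cc2)C(=O)N1c1ccccc1O`) has no reading yet. Its difference from compound 3 is 2,3-dihydroxypropoxy in place of ((dimethylcarbamoyl)methyl)amino on a carbonyl carbon. For the measured compounds named here, no measured pair shows this change, so the expectation rests on values alone. Compound 3, the closest structure, stands at 219000 nM. Going by the values given here, compound 2, the only measured compound with an ester on that carbonyl carbon, stands at 39000 nM, which argues for keeping the low side of the range wide.

In this assay, the expected result is a small downward move, a 1.3-fold lower number from compound 3 to compound 4 (0.11 log units; within the scatter), with no change beyond the scatter expected. For compound 4 the estimated value is 170000 nM, with an expected range of 80000 nM to 300000 nM.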

Compound 4, solubility: > 250000 nM
Compound 4: a limit, no number; the forecaster's own chance of this, stated with the estimate: 10%; middle value at least 1.4-fold (0.16 log units) from the limit.
By their numbers in this assay, from the lowest: compound 2; then compounds 1 and 3 (each within the scatter of the next). At a limit, above all of these: compound 4.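

Compound 4 reads > 250000 nM in this assay, which is a limit of the assay and not a number. Among the compounds shown here, this gives the first step in the set that isolates a single change, an at least 1.1-fold higher number from compound 3 to compound 4 (0.05 log units; that floor lies within the scatter), and it can be read only as a floor, since the true size of the step stays unknown. At this carbonyl carbon, with the rest of compound 3 kept, putting 2,3-dihydroxypropoxy in place of ((dimethylcarbamoyl)methyl)amino brings no fall in the reading: the limit of > 250000 nM in this assay, at which 1 of the 4 values shown sits.

The compounds shown leave open how far compound 4 really lies from compound 3, and whether the same replacement gives the same outcome on the core of compound 1, which differs from compound 3 in more than one place. They also do not show how an amine, a carboxylic acid or a longer chain bearing further hydroxyl groups, each set on this same carbonyl carbon of the core of compound 3, would read in this assay.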